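This account rests on a few compounds, and the source may have more. Where it says the series, first, only, none or still open, it means among the compounds named here.

Compound 1, `Cc1ccn(Cc2c(F)cccc2F)c2nc(-c3c(F)cccc3F)nc1-2`, is recorded at > 100000 nM in an ADME assay on MDBK cells (Bos taurus) for cytotoxicity (on this read-out higher numbers stand for lower toxicity in this test and lower numbers for higher toxicity in this test), a limit of the test. Compound 2, `COc1ccccc1Cn1ccc2nc(-c3ccccc3)nc-2c1`, is recorded at > 100000 nM in this assay, also a limit. Compound 3, `c1ccc(-c2ccc(Cn3ccc4nc(-c5ccccc5)nc-4c3)cc2)cc1`, gives 18000 nM in this assay.

Compound 2 therefore sits at the limit of > 100000 nM in this assay, at which 2 of the 3 values shown sit, a limit rather than a number, and compound 1 sits at the same limit. Compound 4, `c1ccc(-c2nc3ccn(CC4CCCCC4)cc-3n2)cc1`, has not yet been measured; it differs from compound 2 by cyclohexyl in place of 2-methoxyphenyl on a saturated chain carbon bound to an aromatic nitrogen. For the measured compounds named here, no step between measured compounds is recorded here, so nothing ties this change to any shift in this assay. The step expected from compound 2 to compound 4, a number no higher from compound 2 to compound 4 (the limit leaves the size open), is none beyond the scatter. Compound 4 is thus estimated at 100000 nM, within 30000 nM to 300000 nM, and is expected most likely to be reported again as a limit.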

Compound 4, half-maximal cytotoxic concentration: > 100000 nM
Compound 4: only a limit was reported (the forecaster's own chance of this, stated with the estimate: 70%); the middle value lies on the limit itself.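

Compound 2 and compound 4 both stand only as limits in this assay, so no step can be read between them. The compounds shown leave open whether cyclohexyl and 2-methoxyphenyl, on a saturated chain carbon bound to an aromatic nitrogen, differ at all in this assay.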